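The source may report more compounds than this note shows. Statements on the series, on what has been measured and on what is new or still open speak of the compounds shown alone.

In a functional assay on ACHN cells (Homo sapiens) for antiproliferative activity, read by XTT assay (on this read-out lower numbers stand for stronger inhibition and higher numbers for weaker inhibition), compound 1 `O=c1c(Cc2coc3cccc(OCC4CCCCC4)c3c2=O)coc2cc(Cl)ccc12` gives > 10000 nM, which is a limit of the assay and not a number. For the measured compounds named here, compound 2 `COc1ccc2c(=O)c(Cc3coc4cccc(OCC5CCCCC5)c4c3=O)coc2c1` gives 1350 nM, the only true number so far. Methoxy in place of chloro on an aromatic carbon accounts for an at least 7.4-fold lower number from compound 1 to compound 2 (0.86 log units; beyond the scatter), a step beyond the scatter.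

Compound 3 `O=c1c(Cc2coc3cccc(OCC4CCCCC4)c3c2=O)coc2cc(O)ccc12` departs from compound 2 by hydrogen in place of methyl on an oxygen on an aromatic ring, which reads as methoxy to hydroxy. Going by the values given here, the one measured step, an at least 7.4-fold lower number from compound 1 to compound 2 (0.86 log units; beyond the scatter), changes the same substituent, so it suggests that this assay responds to changes there. It gives no direction for this different exchange, and its size is open-ended. The expected change is a 1.5-fold higher number from compound 2 to compound 3 (0.17 log units; within the scatter), a modest estimated move towards weaker inhibition that may not clear the scatter. The estimate for compound 3 is 2000 nM, with an expected range of 600 nM to 9000 nM.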

Compound 3, half-maximal inhibitory concentration: 2100 nM
Beside the measured number, compound 3's estimate is 1.1-fold (0.02 log units) below it; low and high end bracket the measured number.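

In this assay, hydrogen in place of methyl on the oxygen gives a 1.6-fold higher number from compound 2 to compound 3 (0.19 log units; within the scatter), so this exchange does not separate compound 2 from compound 3, and the methyl is not needed to keep the measurable activity seen with compound 2. Hydroxy in place of chloro gives an at least 4.7-fold lower number from compound 1 to compound 3 (0.67 log units; beyond the scatter), a second step beyond the scatter at this substituent, so both oxygen-linked groups now stand apart from chloro. The true size of both steps from chloro stays open because compound 1 sits at a limit of the assay and not at a number: the limit of > 10000 nM in this assay, at which 1 of the 3 values shown sits.

The compounds shown leave open whether an amine at this place would behave like hydroxy and methoxy or like chloro. They also leave open whether a longer chain on the oxygen, such as ethoxy, would keep the values of compound 2 and compound 3.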